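Compound 3 to compound 4: methyl becomes iodo

The source may report more compounds than this note shows. Statements on the series, on what has been measured and on what is new or still open speak of the compounds shown alone.

Antiproliferative readings for this small set come from a functional assay on MGC-803 cells (Homo sapiens) for antiproliferative activity, read by MTT assay, with a stated time of 48 h; a lower number here means that less compound is needed, a higher number that more compound is needed for the effect. In this assay compound 1 (`CC1=NN(C(=O)CCl)C(c2cc(Cl)ccc2O)C1`) gives 12300 nM. Compound 2 (`CC1=NN(C(=O)CBr)C(c2ccccc2O)C1`) gives 3650 nM in the same test. Both carry a halogenated acetyl group on the shared core, whereas compound 3 (`CC1=NN(S(=O)(=O)c2ccccc2C)C(c2cc(Br)ccc2O)C1`) carries an aryl sulfonyl group there.

Compound 3 stands at > 60000 nM, which is a limit of the assay and not a number. Its place in the set is the limit of > 60000 nM in this assay, at which 1 of the 3 values shown sits. Going by the values given here, no measured step connects it to the other two compounds.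

Compound 4 (`CC1=NN(S(=O)(=O)c2ccccc2I)C(c2cc(Br)ccc2O)C1`) departs from compound 3 in one place: iodo in place of methyl on an aromatic carbon. Seen one bond further out, 2-methylphenyl becomes 2-iodophenyl, and the exchange sits on an aromatic carbon, ortho to a large group.

Among the compounds with values here, no measured pair here shows what this exchange does. The expectation therefore starts from compound 3 at > 60000 nM, again a limit. In this assay the estimated step of a number no higher from compound 3 to compound 4 (the limit leaves the size open) is expected to stay within the usual scatter, with no clear direction, and another reading at the limit is quite possible. For compound 4 the expected value is 60000 nM, with an estimated range of 20000 nM to 120000 nM.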

Compound 4, half-maximal effective concentration: 52500 nM
Compound 4: middle estimate off by 1.1-fold (0.06 log units), on the high side, and the stated range covers the measured number.
By their numbers in this assay, from the lowest: compound 2; then compound 1; then compound 4. At a limit, above all of these: compound 3.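

In this assay, iodo in place of methyl on the aromatic carbon gives an at least 1.1-fold lower number from compound 3 to compound 4 (0.05 log units; that floor lies within the scatter), so this position tolerates the change without a shift that can be told from the scatter. Going by these compounds alone, compound 4 gives 52500 nM, a number and not a limit, which provides the first measured reading for a compound with an aryl sulfonyl group on the shared core. Compound 3 remains a limit of the assay and not a number, so the step has a floor and no measured size: the limit of > 60000 nM in this assay, at which 1 of the 4 values shown sits.

The compounds shown leave open whether another group on this aromatic carbon, such as an amine, a carboxylic acid or a methoxy group, would move the reading beyond the scatter. Also open, from the compounds shown here alone, is how compound 1 and compound 2, with their halogenated acetyl groups, relate to compound 3 and compound 4: these compounds differ in more than one place, and the steps between them cannot be read.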